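The source may report more compounds than this note shows. Statements on the series, on what has been measured and on what is new or still open speak of the compounds shown alone.

Compound 1 `COc1cc(Oc2cccc(Nc3ccccc3)c2)cc(OC)c1CNCc1ccccc1` gives 3340 nM in a functional assay on HT-29 cells (Homo sapiens) for inhibition, read by MTT assay, with a stated time of 72 h; a lower number here means a stronger inhibitor, a higher number a weaker inhibitor.
Compound 2 `COc1cc(Oc2cccc(Nc3ccccc3)c2)cc(OC)c1CNCc1ccc(C)cc1` gives 3880 nM in this assay.
Compound 3 `COc1ccc(CCCNCc2c(OC)cc(Oc3cccc(Nc4ccccc4)c3)cc2OC)cc1` gives 3320 nM in this assay.

Compound 2 carries the highest of the three numbers, yet it lies within the scatter of both neighbours: there is a 1.2-fold higher number from compound 1 to compound 2 (0.07 log units; within the scatter) and a 1.2-fold lower number from compound 2 to compound 3 (0.07 log units; within the scatter), and also a 1.0-fold lower number from compound 1 to compound 3 (0.00 log units; within the scatter). All three compounds therefore sit together, and none can be called stronger or weaker than another.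

Compound 4 `COc1cc(Oc2cccc(Nc3ccccc3)c2)cc(OC)c1CCO` differs from compound 2 in one place: hydroxymethyl in place of (4-methylbenzyl)amino on a saturated chain carbon bound to an aromatic carbon. The three measured steps all vary the group on the amine side of the shared core and were each within the scatter, so they show that swapping one aromatic group for another there leaves the number unchanged. None of them removes the amine and its aromatic group altogether, as the step to compound 4 does, so they bear on it only loosely. For compound 4 the step is expected to be a 1.5-fold higher number from compound 2 to compound 4 (0.19 log units; within the scatter), with a wide range because the change has no close precedent among these three. Compound 4 is estimated at 6000 nM, between 2000 nM and 20000 nM.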

Compound 4, half-maximal inhibitory concentration: 13900 nM
Estimate against measurement, compound 4: 2.3-fold (0.36 log units) below; low and high end bracket the measured number.
By their numbers in this assay, from the lowest: compounds 3, 1 and 2 (each within the scatter of the next); then compound 4.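

In this assay swapping one aromatic group for another on the amine side left the number in place, but replacing the whole amine group does move it: there is a 3.6-fold higher number from compound 2 to compound 4 (0.55 log units; beyond the scatter) and a 4.2-fold higher number from compound 1 to compound 4 (0.62 log units; beyond the scatter) and likewise a 4.2-fold higher number from compound 3 to compound 4 (0.62 log units; beyond the scatter) on going to hydroxymethyl. At this place, on a saturated chain carbon bound to an aromatic carbon, compound 1, compound 2 and compound 3 are all stronger inhibitors than compound 4, by steps that are beyond the scatter yet modest. Nothing available accounts for this shift.

Compound 4 loses the amine nitrogen and the aromatic ring together, and the compounds shown do not separate what each contributes. On these data alone, how a primary amine or a benzyl ether would stand at this place also remains open.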